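From 3-methylphenyl to 4-methylphenyl on an aromatic nitrogen

The source may hold more compounds than are shown below. What is called first, only, known or untested is meant among the compounds shown, and "the series" means these compounds.

In an ADME assay on BJ cells (Homo sapiens) for cytotoxicity, with a stated time of 72 h (a lower number here means that less compound is needed, a higher number that more compound is needed for the effect), compound 1 (`CCc1ccc(-c2nc3c(c(C)nn3-c3ccccc3)c(-c3ccccc3O)c2C#N)cc1`) gives > 20000 nM, which is a limit of the assay and not a number. Compound 2 (`CCc1ccc(-c2nc3c(c(C)nn3-c3cccc(C)c3)c(-c3ccccc3O)c2C#N)cc1`) gives > 20000 nM, again only a limit. The record so far is the limit of > 20000 nM in this assay, at which 2 of the 2 values shown sit. Going by the values given here, the one measured step, a step that the two limits leave unreadable from compound 1 to compound 2, therefore offers no size to carry forward.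

Compound 3 (`CCc1ccc(-c2nc3c(c(C)nn3-c3ccc(C)cc3)c(-c3ccccc3O)c2C#N)cc1`) has 4-methylphenyl in place of 3-methylphenyl on an aromatic nitrogen of the shared core: 4-methylphenyl in place of 3-methylphenyl on an aromatic nitrogen. Compound 2, with its limit of > 20000 nM, offers no exact starting point, so no change beyond the scatter is expected in this assay. The expected move is a step that the limit leaves unreadable from compound 2 to compound 3. For compound 3 the estimated value is 25000 nM, with an expected range of 12000 nM to 50000 nM.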

Compound 3, half-maximal effective concentration in the BJ assay: > 20000 nM
Compound 3 gave a limit, no number; the forecaster's own chance of this, stated with the estimate: 85%; the middle value lies beyond the limit too.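

In the BJ assay compound 3 gives > 20000 nM, which is a limit of the assay and not a number. Compound 1 and compound 2 also give only limits, so no step among these three compounds can be read: the limit of > 20000 nM in the BJ assay, at which 3 of the 3 values shown sit. The compounds shown leave open whether adding or moving the methyl group changes this read-out at all. In a physicochemical assay for solubility, read by spectrophotometry, in phosphate buffer, with a stated time of 18 h, at pH 7.4 (on this read-out higher numbers stand for higher solubility and lower numbers for lower solubility), compound 2 gives 4800 nM and compound 3 gives 8900 nM, which is a 1.9-fold higher number from compound 2 to compound 3 (0.27 log units; within the scatter).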